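Cytotoxicity notes on the step to compound 3

The source may report more compounds than this note shows. Statements on the series, on what has been measured and on what is new or still open speak of the compounds shown alone.

Compound 1 `COC(=O)c1cc(-c2cccc(NC(=O)c3ccc(C4OC4C(=O)c4ccc(Cl)cc4)cc3)c2)on1` in an ADME assay on Vero cells (Chlorocebus sabaeus) for cytotoxicity, read by MTT assay, with a stated time of 72 h (on this read-out higher numbers stand for lower toxicity in this test and lower numbers for higher toxicity in this test), gives > 20 ug/mL, which is a limit of the assay.
Compound 2 `COC(=O)c1cc(-c2cccc(NC(=O)c3ccc(/C=C/C(=O)c4ccc(C)cc4)cc3)c2)on1` in this assay gives > 80 ug/mL, likewise a limit.

Compound 2 therefore stands at the upper limit shown, with no number. Among the compounds with values here, the single step in this assay, a step that the two limits leave unreadable from compound 1 to compound 2, cannot be read because both values sit at the limit of > 20 ug/mL in this assay, at which 1 of the 2 values shown sits, and (the limit of > 80 ug/mL in this assay, at which 1 of the 2 values shown sits). Compound 3 `COC(=O)c1cc(-c2cccc(NC(=O)c3ccc(/C=C/C(=O)c4ccc(Cl)cc4)cc3)c2)on1` differs from compound 2 by chloro in place of methyl on an aromatic carbon. Within the data shown here, no measured step in this assay bears on this change, so nothing beyond the scatter is expected, and a number no higher from compound 2 to compound 3 (the limit leaves the size open) is estimated as a flat step. Compound 3 is expected to give about 80 ug/mL, within 40 ug/mL to 160 ug/mL, most likely again reported only as a limit.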

Compound 3, half-maximal cytotoxic concentration: > 50 ug/mL
Compound 3 gave a limit, no number; the forecaster's own chance of this, stated with the estimate: 70%; the middle value is on the limit's open side.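

Within the data shown here, compound 1, compound 2 and compound 3 each give only a limit in this assay, and no step among them can be read. The compounds shown leave open whether chloro in place of methyl on an aromatic carbon changes cytotoxicity at all.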